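The compounds below may be only part of what the source reports. "The series", "measured", "known", "first", "only" and "open" are said of these compounds alone.

Measured so far:
- compound 1 `COc1cc([N+](=O)[O-])ccc1-n1cc(COC2=C(CC=C(C)C)C(=O)c3ccccc3C2=O)nn1`: in an ADME assay on HepG2 cells (Homo sapiens) for cytotoxicity, read by MTT assay, with a stated time of 24 h (a higher number here means that more compound is tolerated, a lower number that less compound is tolerated), compound 1 gives 701000 nM
- compound 2 `COc1ccc(-n2cc(COC3=C(CC=C(C)C)C(=O)c4ccccc4C3=O)nn2)c([N+](=O)[O-])c1`: in this assay compound 2 gives 532000 nM

Compound 2 holds the lower of the two numbers, yet the step of a 1.3-fold lower number from compound 1 to compound 2 (0.12 log units; within the scatter) lies within the scatter, so the two compounds are not separated. Compound 3 `COc1ccc(-n2cc(COC3=C(CC=C(C)C)C(=O)c4ccccc4C3=O)nn2)cc1` differs from compound 2 by hydrogen in place of nitro on an aromatic carbon. Among the compounds with values here, no measured step removes a nitro group; the only one available, a 1.3-fold lower number from compound 1 to compound 2 (0.12 log units; within the scatter), swaps the positions of nitro and methoxy and stays within the scatter. The expected step of a 1.0-fold higher number from compound 2 to compound 3 (0.01 log units; within the scatter) is therefore none beyond the scatter. Compound 3 is estimated at 550000 nM, range 250000 nM to 1200000 nM.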

Compound 3, half-maximal cytotoxic concentration: 200000 nM
The estimate for compound 3 lay 2.8-fold (0.44 log units) above the measured number; measured number outside the range, below it.
By their numbers in this assay, from the lowest: compound 3; then compounds 2 and 1 (each within the scatter of the next).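

In this assay the nitro group on this aromatic carbon now counts: hydrogen in its place gives a step beyond the scatter (a 2.7-fold lower number from compound 2 to compound 3 (0.42 log units; beyond the scatter)), whereas exchanging the positions of nitro and methoxy did not separate the compounds. The change to 4-methoxyphenyl from the other nitro arrangement points the same way (a 3.5-fold lower number from compound 1 to compound 3 (0.54 log units; beyond the scatter)), so 4-methoxyphenyl is less tolerated than either nitro-bearing aryl group. Nothing available explains why the nitro group has this effect. Open, as far as these compounds go, is whether an amine or a carboxylic acid on that carbon would track nitro or hydrogen.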